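Compound 3 to compound 4: replacing 2-chlorophenyl

A few compounds are considered here, and "the series" means these few. Any claim that something is new, unique, unknown or untested is made for them only; others in the source may bear on it.

In a functional assay on SW-620 cells (Homo sapiens) for cytotoxicity, read by MTT assay, with a stated time of 72 h (a lower number here means a stronger inhibitor, a higher number a weaker inhibitor), compound 1 (`COc1ccc(/C=C2\CCC/C(=C\c3cccc(OC)c3OC)C2=O)cc1OC`) gives 6400 nM, compound 2 (`COc1cccc(/C=C2\CCC/C(=C\c3ccc(O)c(O)c3)C2=O)c1OC`) gives 6300 nM and compound 3 (`COc1ccc(/C=C2\CCC/C(=C\c3ccccc3Cl)C2=O)cc1OC`) gives 7100 nM. These three values lie within the scatter of one another, so compound 3 stands level with the other two. Compound 4 (`COc1ccc(/C=C2\CCC/C(=C\c3ccc(OC)c(OC)c3)C2=O)cc1`) has 4-methoxyphenyl in place of 2-chlorophenyl on a double-bonded chain carbon bound to a double-bonded ring carbon. Among the measured compounds shown here, no measured pair differs in one place only, so no measured step bears directly on this change. The step expected in this assay is a 1.1-fold lower number from compound 3 to compound 4 (0.04 log units; within the scatter), none beyond the scatter, with no direction favoured. For compound 4 the estimated value is 6500 nM, with an expected range of 3000 nM to 14000 nM.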

Compound 4, half-maximal inhibitory concentration: 6600 nM
The estimate for compound 4 lay 1.0-fold (0.01 log units) below the measured number; the range from low to high includes it.
By their numbers in this assay, from the lowest: compounds 2, 1, 4 and 3 (each within the scatter of the next).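

In this assay, among the compounds shown here, the only single-place step is a 1.1-fold lower number from compound 3 to compound 4 (0.03 log units; within the scatter), with 4-methoxyphenyl in place of 2-chlorophenyl on a double-bonded chain carbon bound to a double-bonded ring carbon. At this place, a chlorine-bearing phenyl and a methoxy-bearing phenyl are therefore not told apart. No available evidence bears on this level result. Still open, from the compounds shown here alone, is whether an amine or a carboxylic acid on the phenyl at this place would give a step beyond the scatter. Going by these compounds, a longer chain in place of the phenyl is equally open.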